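Ortho-methoxy on the benzyl group: a second look

The source may report more compounds than this note shows. Statements on the series, on what has been measured and on what is new or still open speak of the compounds shown alone.

Compound 1 `COc1cc2sn(CCCCN(C)Cc3ccccc3)c(=O)c2cc1OC` and compound 2 `COc1ccccc1CN(C)CCCCn1sc2cc(OC)c(OC)cc2c1=O` share a core, and compound 3 `COc1cc2sn(CCCCCCN(C)Cc3ccccc3)c(=O)c2cc1OC` carries a longer chain; how the core of compound 3 differs from that of compound 1 is not broken down here. In an assay on isolated protein for inhibition of Amine oxidase [flavin-containing] A (Homo sapiens), read by fluorescence, with a stated time of 30 min (a lower number here means a stronger inhibitor, a higher number a weaker inhibitor), compound 1 gives 8900 nM, compound 2 gives 7100 nM, and compound 3 gives 23000 nM. The change methoxy in place of hydrogen on an aromatic carbon brought a 1.3-fold lower number from compound 1 to compound 2 (0.10 log units; within the scatter). Compound 4 `COc1ccccc1CN(C)CCCCCCn1sc2cc(OC)c(OC)cc2c1=O` arises from compound 3 by the same change, (methoxy in place of hydrogen on an aromatic carbon). Because a 1.3-fold lower number from compound 1 to compound 2 (0.10 log units; within the scatter) was within the scatter, compound 4 is expected in this assay to sit close to compound 3, with an estimated step of a 1.3-fold lower number from compound 3 to compound 4 (0.11 log units; within the scatter). The estimate for compound 4 is therefore 18000 nM, between 8000 nM and 40000 nM.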

Compound 4, half-maximal inhibitory concentration: 19900 nM
The estimate for compound 4 lay 1.1-fold (0.04 log units) below the measured number; low and high end bracket the measured number.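

In this assay, methoxy in place of hydrogen on the benzyl group brought a 1.2-fold lower number from compound 3 to compound 4 (0.06 log units; within the scatter), so the change again left the number within the scatter. The two steps agree: the same change on two cores in this assay, a 1.3-fold lower number (0.10 log units; within the scatter) from compound 1 to compound 2 and a 1.2-fold lower number (0.06 log units; within the scatter) from compound 3 to compound 4, 1.1-fold (0.04 log units) apart, within the scatter of two such steps. This shows that the change behaves alike on these two cores, but only as a step too small to read, and two pairs set no rule for the whole series or show how a larger step would carry over.

The compounds shown leave open whether a chlorine atom or a nitrile on the benzyl group would move the number beyond the scatter. They also leave open whether methoxy would behave the same way on a shorter chain.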